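The source may report more compounds than this note shows. Statements on the series, on what has been measured and on what is new or still open speak of the compounds shown alone.

Measured in a functional assay on MCF7 cells (Homo sapiens) for inhibition, read by sulforhodamine B assay, with a stated time of 72 h; a higher number here means a weaker inhibitor of growth, a lower number a stronger inhibitor of growth:
- compound 1 `CNC(=O)/C=C/c1ccncc1-c1ccc2ccccc2c1`: 9340 nM
- compound 2 `COC(=O)/C=C/c1ccncc1-c1ccc2ccccc2c1`: 8170 nM

Not yet measured: compound 3 `CN(C)C(=O)/C=C/c1ccncc1-c1ccc2ccccc2c1`.

Going by the values given here, with only two measured compounds, compound 2 lies within the scatter of compound 1, so neither stands apart. The next change is dimethylamino in place of methoxy on a carbonyl carbon. Among the compounds with values here, one measured step bears on it: a 1.1-fold lower number from compound 1 to compound 2 (0.06 log units; within the scatter). That exchange at the same carbonyl carbon involved methoxy and methylamino and did not move the number beyond the scatter. Within the data shown here, no measured compound carries dimethylamino, so this is thin support. Even so, no shift beyond the scatter is expected in this assay. The expected step, which stays within the scatter, is a 1.1-fold higher number from compound 2 to compound 3 (0.04 log units; within the scatter). The estimate for compound 3 is 9000 nM, with an expected range of 4500 nM to 18000 nM.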

Compound 3, concentration for 50% growth inhibition: 8190 nM
Compound 3: middle estimate off by 1.1-fold (0.04 log units), on the high side, and the stated range covers the measured number.
By their numbers in this assay, from the lowest: compounds 2, 3 and 1 (each within the scatter of the next).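

Working from this assay, dimethylamino in place of methoxy on the carbonyl carbon gives a 1.0-fold higher number from compound 2 to compound 3 (0.00 log units; within the scatter) and so adds a second exchange at this position that stays within the scatter. Methyl in place of hydrogen on the amide-type nitrogen gives a 1.1-fold lower number from compound 1 to compound 3 (0.06 log units; within the scatter) and shows that the amide hydrogen can go without the number leaving the scatter, a point the earlier pair could not address. No measured evidence bears on why methoxy, methylamino and dimethylamino give numbers within the scatter of one another.

Still open, from the compounds shown here alone, is whether any group on this carbonyl carbon moves the number beyond the scatter, for example a free carboxylic acid, a cyclic amine such as morpholine or a longer chain on the nitrogen. Going by these compounds, the contribution of the shared core also remains open, as all three compounds carry it unchanged.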